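Adding a Methyl to the Anilino Ring

The source may report more compounds than this note shows. Statements on the series, on what has been measured and on what is new or still open speak of the compounds shown alone.

Three compounds share one core. Compound 1 `CCn1c(=O)/c(=C2\Sc3ccccc3N2C)s/c1=C\c1ccncc1Nc1ccccc1C` gives 470 nM in a functional assay on CWR22R cells (Homo sapiens) for inhibition; a higher number here means a weaker inhibitor, a lower number a stronger inhibitor; compound 2 `CCn1c(=O)/c(=C2\Sc3ccccc3N2C)s/c1=C\c1ccncc1Nc1ccccc1Cl` gives 460 nM and compound 3 `CCc1ccc2c(c1)S/C(=c1/s/c(=C\c3ccncc3Nc3ccccc3F)n(CC)c1=O)N2C` gives 1200 nM. Compound 1 thus stands second highest of the three: compound 2 lies within the scatter of it, while compound 3 gives a higher number beyond the scatter. Compound 4 `CCn1c(=O)/c(=C2\Sc3ccccc3N2C)s/c1=C\c1ccncc1Nc1cc(C)ccc1C` differs from compound 1 by methyl in place of hydrogen on an aromatic carbon, turning 2-methylphenyl into 2,5-dimethylphenyl. Among the measured compounds shown here, the only measured step, a 1.0-fold lower number from compound 1 to compound 2 (0.01 log units; within the scatter), concerns a different group and stays within the scatter; compound 3 differs in several places. For the measured compounds named here, no measured step therefore bears directly on this change. The step expected is a 1.0-fold lower number from compound 1 to compound 4 (0.02 log units; within the scatter), nothing beyond the scatter. For compound 4 the estimated value is 450 nM, ranging from 200 nM to 1000 nM.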

Compound 4, half-maximal inhibitory concentration: 1800 nM
Compound 4: middle estimate off by 4.0-fold (0.60 log units), on the low side; the measured number lies above the stated range.
By their numbers in this assay, from the lowest: compounds 2 and 1 (each within the scatter of the next); then compounds 3 and 4 (each within the scatter of the next).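

In this assay, the added methyl is not neutral: it gives a 3.8-fold higher number from compound 1 to compound 4 (0.58 log units; beyond the scatter), so this ring position, meta to a large group and para to a methyl group, does not take a methyl without a loss of activity. Compared with the chloro compound, the 2,5-dimethylphenyl group gives a 3.9-fold higher number from compound 2 to compound 4 (0.59 log units; beyond the scatter), a loss of similar size. Nothing available explains this loss. As far as these compounds go, whether fluoro, methoxy or an amine at this place would give the same result stays open. So does whether the loss would persist with a 2-chlorophenyl ring.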